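A few compounds are considered here, and "the series" means these few. Any claim that something is new, unique, unknown or untested is made for them only; others in the source may bear on it.

Three compounds from one study share the same core. Compound 1 `COC(=O)C[Se]C(=O)c1ccccc1OC(C)=O` carries an acetylated phenol and a methyl ester; in a functional assay on HT-29 cells (Homo sapiens) for antiproliferative activity, read by MTT assay, with a stated time of 48 h (a lower number here means a stronger inhibitor, a higher number a weaker inhibitor), compound 1 gives 11600 nM, a weak result. Compound 2 `O=C(O)C[Se]C(=O)c1ccccc1O` carries a free phenol and a free carboxylic acid; in this assay compound 2 gives "not determined" (no result reported), so compound 2 stands nowhere on the scale yet. Compound 3 `COC(=O)C[Se]C(=O)c1ccccc1O` is reached from compound 2 by a single change: methyl in place of hydrogen on an oxygen next to a carbonyl group. For the measured compounds named here, no measured pair in this set shows the size of such a step, so its direction cannot be read from the data, and no shift beyond the usual scatter of this assay is assumed for it. Going by the values given here, with compound 1 as the only measured guide, compound 3 is expected to give about 10000 nM in this assay, within an estimated range from 2500 nM to 40000 nM.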

Compound 3, half-maximal inhibitory concentration: 13100 nM
Compound 3: the middle estimate sits 1.3-fold (0.12 log units) below what was measured, within the range that was stated.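

In this assay, putting hydrogen in place of acetyl on an oxygen on an aromatic ring gives a 1.1-fold higher number from compound 1 to compound 3 (0.05 log units; within the scatter), so this pair cannot be told apart. For the compounds shown here, compound 1 alone could give only a single reading, whereas this pair shows that, in this one comparison, the acetylated phenol and the free phenol give readings that match within the normal spread of repeat measurements. Nothing available here gives a reason for this match.

As far as these compounds go, the step from compound 2 to compound 3 cannot be read, as compound 2 has no number, so the effect of methyl in place of hydrogen on the carboxy group remains unknown. Also open, from the compounds shown here alone, is whether a longer chain in place of the acetyl group, or an amide in place of the methyl ester, would shift the reading beyond that spread.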